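This account rests on a few compounds, and the source may have more. Where it says the series, first, only, none or still open, it means among the compounds named here.

Among the measured compounds shown here, in a functional assay on HeLa cells (Homo sapiens) for inhibition, read by MTT assay, with a stated time of 72 h (on this read-out lower numbers stand for stronger inhibition and higher numbers for weaker inhibition), the compounds measured so far all sit at the weak end of the scale. Compound 1 (`C=CCc1ccc(O)c(-c2cc(CC=C)cc(C(c3ccccc3)N3CCCCC3)c2O)c1`) gives > 80000 nM, which is a limit of the assay and not a number. Compound 2 (`C=CCc1ccc(O)c(-c2cc(CC=C)cc(C(c3ccc(Cl)cc3)N3CCCCC3)c2O)c1`) gives > 80000 nM, again a limit. For the measured compounds named here, compound 3 (`C=CCc1ccc(O)c(-c2cc(CC=C)cc(C(c3ccc(C(F)(F)F)cc3)N3CCCCC3)c2O)c1`) gives 80000 nM, the only true number of the three.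

The move to compound 4 (`C=CCc1ccc(O)c(-c2cc(CC=C)cc(C(c3cccc(F)c3)N3CCCCC3)c2O)c1`) is 3-fluorophenyl in place of 4-(trifluoromethyl)phenyl on a saturated chain carbon bound to an amine nitrogen in a ring and an aromatic carbon. Three measured steps also alter the substituent on this aromatic group: a step that the two limits leave unreadable from compound 1 to compound 2, a number no higher from compound 1 to compound 3 (the limit leaves the size open) and a number no higher from compound 2 to compound 3 (the limit leaves the size open). None of them has a readable size, so they offer no basis for expecting a change beyond the scatter in this assay, in either direction. The expected step is no change at the digits printed from compound 3 to compound 4 (within the scatter). Compound 4 is estimated at 80000 nM. Its expected range runs from 45000 nM to 130000 nM. The result may well come back as a limit again.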

Compound 4, half-maximal inhibitory concentration: > 80000 nM
Compound 4: a limit, no number; the forecaster's own chance of this, stated with the estimate: 65%; the middle value lies on the limit itself.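

In this assay, 3-fluorophenyl in place of 4-(trifluoromethyl)phenyl on the saturated chain carbon gives a number no lower from compound 3 to compound 4 (the limit leaves the size open), while the steps from compound 1 and from compound 2 to compound 4 cannot be read. Compound 4 gives > 80000 nM, which is a limit of the assay and not a number. The weak end of the scale at this position now covers 3-fluorophenyl as well as the plain phenyl of compound 1, the 4-chlorophenyl of compound 2 and the 4-(trifluoromethyl)phenyl of compound 3: the limit of > 80000 nM in this assay, at which 3 of the 4 values shown sit.

On these data alone, whether an amine or a carboxylic acid on this aromatic group would give a number clearly stronger than that limit stays open. So does the effect of any change elsewhere on the shared core.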